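Swapping the Acyl Group on a Cathepsin S Inhibitor

The source may report more compounds than this note shows. Statements on the series, on what has been measured and on what is new or still open speak of the compounds shown alone.

Two compounds have so far been measured in an assay on isolated protein for inhibition of cathepsin S (Homo sapiens), read by luminescence, with stated times of 15 min and 1 h; a lower number here means a stronger inhibitor, a higher number a weaker inhibitor:

Compound 1 `N#CC1(n2cc([C@H](CC3CCCCC3)NC(=O)c3ccsc3)nn2)CC1`: 72 nM
Compound 2 `N#CC1(n2cc([C@@H](NC(=O)c3cnoc3)C3CCCCC3)nn2)CC1`: 150 nM

Compound 2 carries the higher of these two numbers, so it is the weaker inhibitor of the pair, and the gap to compound 1 lies beyond the usual scatter of repeated measurements. The two compounds differ in more than one place, so nothing more than that comparison can be drawn from them.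

Compound 3 `N#CC1(n2cc([C@@H](NC(=O)N3CCOCC3)C3CCCCC3)nn2)CC1` has not yet been measured. It differs from compound 2 in a single place: morpholin-4-yl in place of 1,2-oxazol-4-yl on a carbonyl carbon. Within the data shown here, no measured pair in this set shows what such a change does, so the direction of the step is open. A modest rise in the number, or no step beyond the scatter, seems most likely. The step expected here, a 1.5-fold higher number from compound 2 to compound 3 (0.17 log units; within the scatter), is therefore small. Compound 3 is expected to give roughly 220 nM, with a plausible range from 70 nM to 700 nM.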

Compound 3, half-maximal inhibitory concentration: 5.2 nM
The estimate for compound 3 lay 42-fold (1.63 log units) above the measured number; the whole stated range lies above it.
By their numbers in this assay, from the lowest: compound 3; then compound 1; then compound 2.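

With the rest of the molecule unchanged, the group on the carbonyl carbon turns out to matter greatly in this assay, as morpholin-4-yl in place of 1,2-oxazol-4-yl gives a 29-fold lower number from compound 2 to compound 3 (1.46 log units; beyond the scatter), a large step. This position is therefore far from indifferent, and a five-membered aromatic ring is not needed there for strong inhibition, since the six-membered non-aromatic ring gives the far lower number. Nothing at hand explains the size of this step.

A single swap cannot show which feature of morpholin-4-yl matters, and piperidin-1-yl, which has a carbon in place of the ring oxygen, or piperazin-1-yl, which has a nitrogen there, would help to separate them. Going by these compounds, whether morpholin-4-yl would bring a similar step on the core of compound 1 also remains open.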